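The source may hold more compounds than are shown below. What is called first, only, known or untested is meant among the compounds shown, and "the series" means these compounds.

Of the compounds shown here, three built on one shared core have so far been tested in an ADME assay on HEL cells (Homo sapiens) for cytotoxicity; a lower number here means that less compound is tolerated, a higher number that more compound is tolerated. Compound 1 `Cc1ccc(/C=N/NC(=O)COc2cccc3ccccc23)cc1` gives 20 ug/mL. Compound 2 `O=C(COc1cccc2ccccc12)N/N=C/c1cccc(O)c1` gives 100 ug/mL. Compound 3 `O=C(COc1cccc2ccccc12)N/N=C/c1ccccc1` gives 100 ug/mL. On these numbers compound 3 stands level with compound 2, the pair together at the top of the set, while the remaining gap in the set is a 5.0-fold higher number from compound 1 to compound 3 (0.70 log units; beyond the scatter).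

Compound 4 `O=C(COc1cccc2ccccc12)N/N=C/c1cccc(Br)c1` has not yet been measured. Its change from compound 3 is bromo in place of hydrogen on an aromatic carbon; cut one bond further out, the same change reads phenyl to 3-bromophenyl.

For the measured compounds named here, two measured steps bear on this. The step of no change at the digits printed from compound 2 to compound 3 (within the scatter) shows that a hydroxy at the same place on the ring made no difference beyond the scatter. The step of a 5.0-fold higher number from compound 1 to compound 3 (0.70 log units; beyond the scatter) shows that removing a methyl from the ring gave a clearly higher number, so a substituent on that ring can move the result. The step of a 5.0-fold higher number from compound 1 to compound 2 (0.70 log units; beyond the scatter) compares one substituted ring with another and points the same way. Weighing these, either no change beyond the scatter or a modest fall seems the more likely outcome. Compound 4 is therefore expected to give 50 ug/mL, within a range from 20 ug/mL to 100 ug/mL. That estimate corresponds to an expected step of a 2.0-fold lower number from compound 3 to compound 4 (0.30 log units; within the scatter).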

Compound 4, minimum cytotoxic concentration: 100 ug/mL
For compound 4 the middle estimate is 2.0-fold (0.30 log units) below the measured one; low and high end bracket the measured number.
By their numbers in this assay, from the lowest: compound 1; then compounds 2, 3 and 4 (each within the scatter of the next).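

In this assay bromo in place of hydrogen on an aromatic carbon gives no change at the digits printed from compound 3 to compound 4 (within the scatter) and bromo in place of hydroxy gives no change at the digits printed from compound 2 to compound 4 (within the scatter) on the same ring, so at this place hydrogen, hydroxy and bromo now give the same printed number, and a single heavy atom as large as bromine leaves the result unmoved. For the compounds shown here, the one compound that stands apart is still the one with the 4-methylphenyl group, with a 5.0-fold higher number from compound 1 to compound 4 (0.70 log units; beyond the scatter) when 3-bromophenyl takes its place, but this step changes both the group and where it sits, so it cannot say which of the two matters. No measurement here offers an explanation for why these ring changes behave as they do.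

The compounds shown leave open whether a methyl at the place now held by bromo, as in 3-methylphenyl, would behave like bromo or like the 4-methylphenyl group, and whether bromo at the place held by methyl would match compound 1 or compound 4. They also leave open whether an amine or a carboxylic acid on this ring, or a longer chain linking it to the rest of the shared core, would keep the number level with these three compounds.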